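Pyrrolidinyl for piperidinyl, repeated on a second core

A few compounds are considered here, and "the series" means these few. Any claim that something is new, unique, unknown or untested is made for them only; others in the source may bear on it.

Compound 1 `Cc1cccc(/C(N)=N/NC(=S)N2CCCCC2)n1` and compound 2 `Cc1cccc(/C(N)=N/NC(=S)N2CCCC2)n1` share one core; compound 3 `Cc1ccnc(/C(N)=N/NC(=S)N2CCCCC2)c1` and compound 4 `Cc1ccnc(/C(N)=N/NC(=S)N2CCCC2)c1` share another. Compound 1 and compound 3 are built from the same atoms joined differently, and the difference between the two cores is not broken down here.

In a functional assay on MCF7 cells (Homo sapiens) for cytotoxicity, read by MTT assay, with a stated time of 72 h, tested at 1 uM (a higher number here means more inhibition of growth at the concentration tested, a lower number less inhibition of growth), compound 1 gives 19.5%. Compound 2 gives 17.4%. Compound 3 gives 21.2%. The three values lie within the scatter of one another, so no order among them is claimed.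

The change from compound 1 to compound 2 is pyrrolidin-1-yl in place of piperidin-1-yl on a thiocarbonyl carbon, and it made a step of a number 2.1 percentage points lower from compound 1 to compound 2 (within the scatter). The change from compound 3 to compound 4 is pyrrolidin-1-yl in place of piperidin-1-yl on a thiocarbonyl carbon. The two place lines read the same word for word, so this is the same change, occurring twice among the compounds shown.

Compound 4 has not been measured in this assay. Within the data shown here, the change has only one earlier measured instance, and that instance stayed small because a number 2.1 percentage points lower from compound 1 to compound 2 (within the scatter) gave no movement beyond the scatter. On that basis the step from compound 3 to compound 4 is expected to be small as well. For compound 4 the expected step is a number 2.2 percentage points lower from compound 3 to compound 4 (within the scatter). Compound 4 is therefore estimated at 19%, with an expected range from 9% to 29%.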

Compound 4, percent growth inhibition at one concentration: 49%
For compound 4 the middle estimate is 30 percentage points below the measured one, outside the stated range (above it).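

In this assay, pyrrolidin-1-yl in place of piperidin-1-yl on a thiocarbonyl carbon gave a step of a number 27.8 percentage points higher from compound 3 to compound 4 (beyond the scatter), so the change did not behave alike on the two cores: the same change on two cores in this assay, a number 2.1 percentage points lower (within the scatter) from compound 1 to compound 2 and a number 27.8 percentage points higher (beyond the scatter) from compound 3 to compound 4, 29.9 percentage points apart, beyond the scatter of two such steps

For this change, then, a step read on the core of compound 1 is not a safe guide to the step on the core of compound 3, and any transfer between these two cores has to be checked pair by pair. Among these compounds, the result does not show why the two cores part, since each core supplies only one pair, and it says nothing about how the same change would behave on any further core.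

The compounds shown leave open whether the higher number belongs to the pyrrolidin-1-yl group on this core alone or would also appear with another amine on the same thiocarbonyl carbon, such as morpholin-4-yl or azepan-1-yl, on both cores. Going by these compounds, with each compound read at a single concentration, it also remains open how compound 4 would stand across a full concentration series.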